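The source may report more compounds than this note shows. Statements on the series, on what has been measured and on what is new or still open speak of the compounds shown alone.

Compound 1, with the structure `S=C(SCc1cn(Cc2ccccc2Cl)nn1)N1CCNCC1`, is recorded in a functional assay on PC-3 cells (Homo sapiens) for inhibition, read by MTT assay, with a stated time of 72 h (a higher number here means a weaker inhibitor, a lower number a stronger inhibitor), as "not determined" (no result reported), so there is no number to place it by. Its closest relative among the measured compounds is compound 2, with the structure `O=C(OCc1ccccc1)N1CCN(C(=S)SCc2cn(Cc3ccccc3Cl)nn2)CC1`, in which the free ring nitrogen of the shared core carries a benzyloxycarbonyl group. In this assay compound 2 gives > 128000 nM, which is a limit of the assay and not a number. Among the measured compounds shown here, all that the measured data offer is therefore (the limit of > 128000 nM in this assay, at which 1 of the 2 values shown sits), and the only known relative of compound 1 shows no measurable inhibition.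

Compound 3, with the structure `COc1ccc(Cn2cc(CSC(=S)N3CCNCC3)nn2)cc1`, keeps the core of compound 1 and differs from it in one place: 4-methoxyphenyl in place of 2-chlorophenyl on a saturated chain carbon bound to an aromatic nitrogen. For the measured compounds named here, no measured pair tells how such a swap moves the numbers in this assay, so no step beyond the usual scatter is expected in either direction, and the one measured relative points toward weak inhibition. Compound 3 is therefore expected to give about 100000 nM in this assay, with a likely range from 20000 nM to 300000 nM, and a real chance that only a limit is reported.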

Compound 3, half-maximal inhibitory concentration: > 128000 nM
Compound 3: no number, only a limit; the forecaster's own chance of this, stated with the estimate: 55%; middle value at least 1.2-fold (0.10 log units) from the limit.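

In this assay compound 3 gives > 128000 nM, which is a limit of the assay and not a number. Among the compounds shown here, compound 1 has no number either, so no step between compound 1 and compound 3 can be read. The values shown stand as follows: the limit of > 128000 nM in this assay, at which 2 of the 3 values shown sit. The compounds shown leave open whether 2-chlorophenyl and 4-methoxyphenyl differ at all in their effect on inhibition.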